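The source may report more compounds than this note shows. Statements on the series, on what has been measured and on what is new or still open speak of the compounds shown alone.

Compound 3 `C(=C/c1ccco1)\c1cc(-c2ccco2)cc(-c2cccs2)n1` stands level with compound 1 `c1coc(-c2ccnc(-c3cccs3)c2)c1` and compound 2 `c1ccc(-c2cc(-c3cccs3)nc(-c3cccs3)c2)nc1` in a functional assay on A549 cells (Homo sapiens) for antiproliferative activity; on this read-out lower numbers stand for an effect already at smaller amounts and higher numbers for an effect only at larger amounts of compound: compound 3 gives 118000 nM, compound 1 gives 118000 nM and compound 2 gives 118000 nM. Among the compounds with values here, the one step that joins two of these, no change at the digits printed from compound 1 to compound 3 (within the scatter), lies within the scatter. Compound 4 `c1coc(-c2cc(-c3cccs3)nc(-c3cccs3)c2)c1` differs from compound 3 by thiophen-2-yl in place of 2-(furan-2-yl)ethenyl on an aromatic carbon. Within the data shown here, no measured step swaps these two groups, but compound 2, which also carries two thiophen-2-yl groups, sits at the same level as compound 3, and the earlier step left the read-out unchanged. Compound 4 is therefore expected to show no step beyond the scatter, no change at the digits printed from compound 3 to compound 4 (within the scatter). The estimate for compound 4 in this assay is 118000 nM, within 60000 nM to 200000 nM.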

Compound 4, half-maximal effective concentration: 118000 nM
Beside the measured number, compound 4's estimate shows no gap at the digits printed; the range from low to high includes it.
By their numbers in this assay, from the lowest: compounds 1, 2, 3 and 4 (each within the scatter of the next).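

Swapping 2-(furan-2-yl)ethenyl for thiophen-2-yl on the aromatic carbon next to the ring nitrogen gives no change at the digits printed from compound 3 to compound 4 (within the scatter) in this assay, so the double bond outside aromatic rings is not needed to hold this level. Adding thiophen-2-yl in place of hydrogen on an aromatic carbon gives no change at the digits printed from compound 1 to compound 4 (within the scatter), and furan-2-yl in place of pyridin-2-yl gives no change at the digits printed from compound 2 to compound 4 (within the scatter). Nothing available explains this flatness. Going by these compounds, it remains open whether an amine or a carboxylic acid at this position would move the read-out at all.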